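Swapping an octyl chain for a phenyl ring

The compounds below may be only part of what the source reports. "The series", "measured", "known", "first", "only" and "open" are said of these compounds alone.

In a functional assay on NUGC-3 cells (Homo sapiens) for cytotoxicity, read by sulforhodamine B assay, with a stated time of 72 h (on this read-out lower numbers stand for stronger inhibition of growth and higher numbers for weaker inhibition of growth), compound 2 `CCCCCCCCC(=O)N1c2ccccc2CCC1C(=O)Nc1cc(C(F)(F)F)cc(C(F)(F)F)c1` gives 2230 nM. Among the compounds with values here, the only other measured compound, compound 1 `O=C(Nc1cc(C(F)(F)F)cc(C(F)(F)F)c1)C1CCc2ccccc2N1C(=O)c1ccc(Cl)cc1`, gives 1660 nM, and the step of a 1.3-fold higher number from compound 1 to compound 2 (0.13 log units; within the scatter) lies within the scatter, so compound 2 stands level with it. Compound 3 `O=C(Nc1cc(C(F)(F)F)cc(C(F)(F)F)c1)C1CCc2ccccc2N1C(=O)c1ccccc1` differs from compound 2 by phenyl in place of octyl on a carbonyl carbon. Because the step of a 1.3-fold higher number from compound 1 to compound 2 (0.13 log units; within the scatter) changed the same carbonyl carbon without moving the number beyond the scatter, compound 3 is expected to give 1800 nM, between 900 nM and 3600 nM. The expected step of a 1.2-fold lower number from compound 2 to compound 3 (0.09 log units; within the scatter) is estimated to stay within the scatter.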

Compound 3, concentration for 50% growth inhibition: 1680 nM
Compound 3: middle estimate off by 1.1-fold (0.03 log units), on the high side; the measured number falls inside the stated range.
By their numbers in this assay, from the lowest: compounds 1, 3 and 2 (each within the scatter of the next).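

The carbonyl carbon tolerates more variety than the first pair showed: replacing octyl with a plain phenyl ring leaves the number within the scatter (a 1.3-fold lower number from compound 2 to compound 3 (0.12 log units; within the scatter)). Removing the chloro from the aromatic carbon also changes nothing that can be read (a 1.0-fold higher number from compound 1 to compound 3 (0.01 log units; within the scatter)), so the 4-chlorophenyl and phenyl groups stand level here. No measured evidence explains why these changes leave the number level.

Going by these compounds, whether a methyl group, a longer chain, an amine or a carboxylic acid at this carbonyl carbon would move the number beyond the scatter stays open. Changes elsewhere on the shared core also remain open.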